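The source may report more compounds than this note shows. Statements on the series, on what has been measured and on what is new or still open speak of the compounds shown alone.

Going by the values given here, compound 1 `CCOC(=O)c1nn(-c2ccc(OCC)cc2)cc1O` gives 67% in an assay on isolated protein for inhibition of patatin-like phospholipase domain-containing protein 2 (Mus musculus), tested at 200 uM (on this read-out higher numbers stand for more inhibition at the one concentration tested (going by the name of the read-out) and lower numbers for less inhibition), the lowest of the two numbers measured so far. Its nearest neighbour is compound 2 `CCCCOC(=O)c1nn(-c2ccc(OCC)cc2)cc1O`, which gives 74% in this assay , a step of a number 7 percentage points higher from compound 1 to compound 2 (within the scatter). Compound 3 `CCOC(=O)c1ccn(-c2ccc(OCC)cc2)n1` differs from compound 1 in one place: hydrogen in place of hydroxy on an aromatic carbon. Among the compounds with values here, the single measured step, from compound 1 to compound 2, alters the ester chain and leaves the ring untouched, so no measured step bears on this change. The expected step in this assay is therefore uncertain and estimated at a number 22 percentage points lower from compound 1 to compound 3 (beyond the scatter). Compound 3 is expected to give 45%, within 10% to 80%.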

Compound 3, a percentage reported as inhibition, at one concentration (the size of the read-out at that concentration, not a potency): 89%
For compound 3 the middle estimate is 44 percentage points below the measured one, outside the stated range (above it).
By their numbers in this assay, from the lowest: compounds 1 and 2 (each within the scatter of the next); then compound 3.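

Taking the hydroxy off the aromatic carbon next to the ring atom that bears an ethoxycarbonyl group does not cost inhibition: in this assay the change to hydrogen gives a number 22 percentage points higher from compound 1 to compound 3 (beyond the scatter), a step beyond the scatter. The hydroxy at this position is therefore not required for inhibition at the one concentration tested, which the ester-chain step could not show. No measurement given here accounts for this rise.

On these data alone, whether a methoxy group, an amine or fluorine at this position would match hydrogen remains open. So does whether the longer ester chain of compound 2 would behave the same way without the hydroxy.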